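Thioether aryl swap in the shared core: expectation for compound 4

The compounds below may be only part of what the source reports. "The series", "measured", "known", "first", "only" and "open" are said of these compounds alone.

Measured compounds:
compound 1 `Cc1cc(Nc2cc(-c3ccccc3)[nH]n2)n2nc(SCc3ccc([N+](=O)[O-])cc3)nc2n1` gives 7980 nM in a functional assay on PC-9 cells (Homo sapiens) for inhibition, read by MTT assay, with a stated time of 72 h; on this read-out lower numbers stand for stronger inhibition and higher numbers for weaker inhibition
compound 2 `Cc1cc(Nc2cc(-c3ccccc3)[nH]n2)n2nc(SCc3ccccc3Br)nc2n1` gives 5630 nM in this assay
compound 3 `C=CCSc1nc2nc(C)cc(Nc3cc(-c4ccccc4)[nH]n3)n2n1` reaches only > 50000 nM in this assay, which is a limit of the assay and not a number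

Compound 1 holds the highest of the two numbers shown, with compound 2 its nearest neighbour; the step of a 1.4-fold lower number from compound 1 to compound 2 (0.15 log units; within the scatter) stays within the scatter, so the two aryl variants cannot be ordered. The two steps that replace the aryl group with vinyl read an at least 6.2-fold higher number from compound 1 to compound 3 (0.79 log units; beyond the scatter) and an at least 8.8-fold higher number from compound 2 to compound 3 (0.94 log units; beyond the scatter), both beyond the scatter, resting on (the limit of > 50000 nM in this assay, at which 1 of the 3 values shown sits).

Compound 4 `Cc1cc(Nc2cc(-c3ccccc3)[nH]n2)n2nc(SCc3csc4ccccc34)nc2n1` is not yet measured. Against compound 1 the change is 1-benzothiophen-3-yl in place of 4-nitrophenyl on a saturated chain carbon bound to a sulfur. The bearing precedents are the steps at the same saturated chain carbon bound to a sulfur: an aryl-for-aryl exchange, a 1.4-fold lower number from compound 1 to compound 2 (0.15 log units; within the scatter), moved nothing beyond the scatter, while loss of the aromatic group, an at least 6.2-fold higher number from compound 1 to compound 3 (0.79 log units; beyond the scatter), cost heavily. Compound 4 keeps an aromatic group at that position, so no step beyond the scatter is expected. Compound 4 is estimated at 4500 nM, with a range of 1500 nM to 15000 nM. This estimate means an expected 1.8-fold lower number from compound 1 to compound 4 (0.25 log units; within the scatter).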

Compound 4, half-maximal inhibitory concentration: 4420 nM
For compound 4 the middle estimate is 1.0-fold (0.01 log units) above the measured one; measured number inside the range.
By their numbers in this assay, from the lowest: compounds 4, 2 and 1 (each within the scatter of the next). At a limit, above all of these: compound 3.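

In this assay, the 1-benzothiophen-3-yl group, which has a five-membered aromatic ring as well as a six-membered one, is accepted on the saturated chain carbon bound to a sulfur with no step beyond the scatter: a 1.8-fold lower number from compound 1 to compound 4 (0.26 log units; within the scatter), and a 1.3-fold lower number from compound 2 to compound 4 (0.11 log units; within the scatter). The earlier aromatic examples each carried a single six-membered ring, so compounds 1, 2 and 4 now show that a second ring, and a sulfur-containing ring in place of the 4-nitrophenyl group, leave the number within the scatter. The step from the vinyl compound, an at least 11-fold lower number from compound 3 to compound 4 (1.05 log units; beyond the scatter), repeats the separation from compound 3 with a third aromatic group, and it is read from a limit of the assay and not a number: the limit of > 50000 nM in this assay, at which 1 of the 4 values shown sits.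

The compounds shown leave open whether an aromatic ring as such is what separates compounds 1, 2 and 4 from compound 3, since a saturated ring such as cyclohexyl would be needed to tell this. They also leave open whether an amine or a carboxylic acid on the aromatic ring could move the number beyond the scatter from that of compound 4.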